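Chloro in place of hydrogen on two different aryl piperazines

A few compounds are considered here, and "the series" means these few. Any claim that something is new, unique, unknown or untested is made for them only; others in the source may bear on it.

Three compounds sharing one core were measured in an assay on CHO cells with metabotropic glutamate receptor 2 (Homo sapiens) as the target, read by FLIPR; a higher number here means a larger maximal response, a lower number a smaller maximal response. Compound 3 `Cn1c(CN2CCN(c3ccccc3F)CC2)nc2ccccc21` gives 64%. Compound 1 `Cn1c(CN2CCN(c3ccc(Cl)cc3F)CC2)nc2ccccc21` carries the change chloro in place of hydrogen on an aromatic carbon on the core of compound 3, and compound 1 gives 69%; the step is a number 5 percentage points higher from compound 3 to compound 1 (within the scatter). Compound 2 `Cn1c(CN2CCN(c3ccc(C(F)(F)F)cn3)CC2)nc2ccccc21` gives 81%, the highest of the three numbers, lying beyond the scatter above both compound 1 and compound 3. The difference between the core of compound 2 and the core of compound 3 is not broken down here.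

Compound 4 `Cn1c(CN2CCN(c3ncc(C(F)(F)F)cc3Cl)CC2)nc2ccccc21` has not yet been measured in this assay. It differs from compound 2 by chloro in place of hydrogen on an aromatic carbon. Going by the values given here, this is the same kind of change as the one from compound 3 to compound 1, but the surroundings differ: in compound 1 the chloro sits on a six-membered aromatic ring of carbon only, meta to a fluoro group and para to a large group, whereas in compound 4 it sits on a six-membered aromatic ring with one nitrogen, ortho to a large group, two atoms from the ring nitrogen and meta to a trifluoromethyl group.

The expectation for compound 4 rests on compound 1, whose step a number 5 percentage points higher from compound 3 to compound 1 (within the scatter) stayed within the scatter. The step from compound 2 to compound 4 is therefore estimated as a number 3 percentage points higher from compound 2 to compound 4 (within the scatter). For compound 4 a maximal response of 84% is expected in this assay, with a likely range from 68% to 100%.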

Compound 4, largest response reached (Emax), in percent of the reference or control that the assay uses: 71%
For compound 4 the middle estimate is 13 percentage points above the measured one, and the stated range covers the measured number.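

In this assay, chloro in place of hydrogen on an aromatic carbon gives a number 10 percentage points lower from compound 2 to compound 4 (within the scatter), and when this step is set beside the earlier one, the same change does not behave alike on the two cores: the same change on two cores in this assay, a number 5 percentage points higher (within the scatter) from compound 3 to compound 1 and a number 10 percentage points lower (within the scatter) from compound 2 to compound 4, 15 percentage points apart, beyond the scatter of two such steps This shows that, in this small set, a step measured on the core of compound 3 cannot be carried over as a fixed amount to the core of compound 2, even though each step taken alone stays within the scatter. It does not show what lies behind the gap, nor does it establish a rule for the series, as it rests on one pair of compounds per core, and the two pairs differ both in the ring that carries the chloro and in the groups around it.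

The compounds shown leave open whether the gap follows the ring nitrogen, the trifluoromethyl group or the fluoro group, as no pair here changes one of these while the chloro step is repeated. They also leave open how a bromo, a methyl or a nitrile in place of the same hydrogen would compare with chloro on either core.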